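Working notes: alpha-hydroxy amides on a shared bicyclic core

A few compounds are considered here, and "the series" means these few. Any claim that something is new, unique, unknown or untested is made for them only; others in the source may bear on it.

Of the compounds shown here, two have been measured in a functional assay on a cell-free system (plasma, Homo sapiens), with a stated time of 3 min; a lower number here means a stronger inhibitor, a higher number a weaker inhibitor. Compound 1 `CC1(C[C@@H](O)C(=O)N2C[C@H]3C[C@H]3[C@H]2C(=O)NCc2cc(Cl)ccc2-n2cnnn2)CC1` gives 500 nM in this assay and stands lowest of the two numbers. Compound 2 `O=C(NCc1cc(Cl)ccc1-n1cnnn1)[C@@H]1[C@H]2C[C@H]2CN1C(=O)[C@H](O)Cc1ccccc1` gives 1200 nM in this assay; the gap between compound 1 and compound 2 lies beyond the usual scatter, so compound 1 is the stronger inhibitor of the pair. Both carry the same core and the same hydroxyl-bearing acyl group, and differ only in what sits on the saturated chain carbon bound to the carbonyl carbon and the oxygen.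

Compound 3 `O=C(NCc1cc(Cl)ccc1-n1cnnn1)[C@@H]1[C@@H]2C[C@@H]2CN1C(=O)[C@H](O)c1ccccc1F` has not been measured. It differs from compound 1 as follows: 2-fluorophenyl in place of (1-methylcyclopropyl)methyl on a saturated chain carbon bound to a carbonyl carbon and an oxygen on a saturated carbon. Going by the values given here, no measured pair isolates this change, and the only comparison at this position, compound 1 against compound 2, shows that the larger aromatic-bearing group gives the higher number.

For compound 3 in this assay a weaker inhibitor than compound 1 is expected, with an estimated step of a 3.0-fold higher number from compound 1 to compound 3 (0.48 log units; beyond the scatter) that goes beyond the scatter. The estimate for compound 3 in this assay is 1500 nM, within a range from 400 nM to 6000 nM.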

Compound 3, half-maximal inhibitory concentration: 580 nM
Estimate against measurement, compound 3: 2.6-fold (0.41 log units) above; low and high end bracket the measured number.
By their numbers in this assay, from the lowest: compounds 1 and 3 (each within the scatter of the next); then compound 2.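

In this assay, the step of a 1.2-fold higher number from compound 1 to compound 3 (0.06 log units; within the scatter) shows that 2-fluorophenyl can take the place of (1-methylcyclopropyl)methyl on this saturated chain carbon with no change beyond the scatter, although the entering group has more heavy atoms and brings an aromatic ring. The earlier comparison therefore does not extend to every aromatic-bearing group at this position: compound 2, which also carries an aromatic ring here, gives 1200 nM, while compound 3 goes against any simple link between an aromatic ring at this position and a weaker inhibitor. No available measurement explains why compound 1 and compound 3 give values within the scatter of each other.

The compounds shown leave open what the fluorine of compound 3 contributes, as a plain phenyl group directly at this position would be needed to isolate it. They also leave open how this position responds to groups of a different kind, such as an amine, a carboxylic acid or a longer alkyl chain.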